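The source may report more compounds than this note shows. Statements on the series, on what has been measured and on what is new or still open speak of the compounds shown alone.

Series notes. In an assay on HEK293 cells for binding affinity to Neuropeptide Y receptor type 5 (Homo sapiens), read by radioligand binding (on this read-out higher numbers stand for weaker inhibition and lower numbers for stronger inhibition), compound 1 `Cc1cccc(-n2nc(C(=O)Nc3cc(Cl)cc(Cl)c3)cc2C)c1` gives 218 nM. For compound 2 `COc1cccc(-n2nc(C(=O)Nc3cc(Cl)cc(Cl)c3)cc2C)c1` the assay reports only a limit, > 1000 nM, and no number. Among the measured compounds shown here, the one measured step, an at least 4.5-fold higher number from compound 1 to compound 2 (0.66 log units; beyond the scatter), is itself bounded by the limit of > 1000 nM in this assay, at which 1 of the 2 values shown sits, so where compound 2 stands is known only as that limit and not as a value. Compound 3 `Cc1cc(C(=O)Nc2cc(Cl)cc(Cl)c2)nn1-c1ccccn1` differs from compound 2 by pyridin-2-yl in place of 3-methoxyphenyl on an aromatic nitrogen. The step from compound 1 to compound 2 touches the same position and shows that a change there can move the number beyond the scatter, but it does not tell the direction for the group that enters here, which carries no methoxy. For compound 3 the estimate is therefore 600 nM, with a range of 150 nM to 3000 nM. This estimate implies an expected step of an at least 1.6-fold lower number from compound 2 to compound 3 (0.22 log units; that floor lies within the scatter), uncertain because compound 2 is known only at the limit > 1000 nM.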

Compound 3, half-maximal inhibitory concentration: > 1000 nM
Compound 3: no number, only a limit; the forecaster's own chance of this, stated with the estimate: 35%; middle value at least 1.6-fold (0.22 log units) from the limit.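

Compound 3 is reported in this assay only as a limit, > 1000 nM, and no number. Pyridin-2-yl in place of 3-methylphenyl on the aromatic nitrogen gives an at least 4.5-fold higher number from compound 1 to compound 3 (0.66 log units; beyond the scatter), so a group without a methoxy also gives a higher number than the 3-methylphenyl group, which is the only one of the three groups here with a measured value. The step between the two limits cannot be read, which leaves 3-methoxyphenyl and pyridin-2-yl unordered at this position: the limit of > 1000 nM in this assay, at which 2 of the 3 values shown sit.

Where the values of compound 2 and compound 3 actually lie remains open. Going by these compounds, it is also open whether the methyl group itself matters, which an unsubstituted phenyl or a 3-ethylphenyl on the same aromatic nitrogen could address.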